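The source may report more compounds than this note shows. Statements on the series, on what has been measured and on what is new or still open speak of the compounds shown alone.

Compound 3 `CC(C(=O)NCc1ccc(C(F)(F)Cl)nc1OCc1ccccc1)c1ccc(NS(C)(=O)=O)c(F)c1` gives 0.9 nM in an assay on CHO cells for antagonist activity at transient receptor potential cation channel subfamily V member 1 (Homo sapiens), read by FLIPR; on this read-out higher numbers stand for weaker inhibition and lower numbers for stronger inhibition. Among the compounds with values here, on that read-out compound 3 stands second highest of the three numbers measured so far: compound 1 `CC(C(=O)NCc1ccc(C(F)(F)Cl)nc1N1CCCCC1)c1ccc(NS(C)(=O)=O)c(F)c1` gives 1.3 nM, and compound 2 `CC(C)COc1nc(C(F)(F)Cl)ccc1CNC(=O)C(C)c1ccc(NS(C)(=O)=O)c(F)c1` gives 0.6 nM. Both of those values sit within the scatter of compound 3, so no order among the three can be claimed. The step to compound 4 `CC(C(=O)NCc1ccc(C(F)(F)Cl)nc1SC1CCCCC1)c1ccc(NS(C)(=O)=O)c(F)c1` is cyclohexylsulfanyl in place of benzyloxy on an aromatic carbon. Within the data shown here, three measured steps bear on the same position. a 1.4-fold lower number from compound 1 to compound 3 (0.16 log units; within the scatter) and a 1.5-fold higher number from compound 2 to compound 3 (0.18 log units; within the scatter) both fall within the scatter, and only a 2.2-fold lower number from compound 1 to compound 2 (0.34 log units; beyond the scatter) reaches a modest size. Across piperidin-1-yl, isobutoxy and benzyloxy the spread at this position is therefore small, and nothing in the present data suggests that a cyclohexylsulfanyl group would behave differently. The expected step is a 1.1-fold higher number from compound 3 to compound 4 (0.05 log units; within the scatter), which amounts to no change beyond the scatter. The estimate for compound 4 in this assay is 1 nM, within a range from 0.4 nM to 2.5 nM.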

Compound 4, inhibition constant: 3 nM
For compound 4 the middle estimate is 3.0-fold (0.48 log units) below the measured one; measured number above the stated range.
By their numbers in this assay, from the lowest: compounds 2, 3 and 1 (each within the scatter of the next, the first and the last beyond it); then compound 4.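

In this assay, within the data shown here, this position proves less indifferent than the earlier compounds suggested, with a 3.3-fold higher number from compound 3 to compound 4 (0.52 log units; beyond the scatter) and a 5.0-fold higher number from compound 2 to compound 4 (0.70 log units; beyond the scatter) and also a 2.3-fold higher number from compound 1 to compound 4 (0.36 log units; beyond the scatter) all beyond the scatter, though each is only modest in size. Cyclohexylsulfanyl is thus the first group here to stand apart from every other group shown, leaving compound 4 the weakest inhibitor of the four, whereas piperidin-1-yl, isobutoxy and benzyloxy differed by little among themselves. No available evidence accounts for this shift.

Benzyloxy to cyclohexylsulfanyl changes both the linking atom, oxygen to sulfur, and the ring, aromatic to non-aromatic, so the compounds shown cannot separate the two changes. A cyclohexyloxy or a benzylsulfanyl group at this position would be needed to tell them apart.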